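Working notes on a substituent swap at one aromatic carbon

The compounds below may be only part of what the source reports. "The series", "measured", "known", "first", "only" and "open" are said of these compounds alone.

Compound 2 `CC(C)Cc1cc2oc(=O)n(CCC(=O)O)c2cc1Cl` gives 12.6 nM in an assay for inhibition of kynurenine 3-monooxygenase (Homo sapiens), read by mass spectrometry, with a stated time of 1 h; on this read-out lower numbers stand for stronger inhibition and higher numbers for weaker inhibition. Among the compounds with values here, of the two numbers measured so far it stands highest, but its nearest neighbour, compound 1 `O=C(O)CCn1c(=O)oc2cc(Cl)c(Cl)cc21`, gives 6.31 nM in this assay, and the gap between the two lies within the scatter. Within the data shown here, the single step recorded, a 2.0-fold higher number from compound 1 to compound 2 (0.30 log units; within the scatter), is the one that bears on the present change: replacing chloro with isobutyl on that aromatic carbon moved the read-out by no more than the scatter allows. Compound 3 `COc1cc2oc(=O)n(CCC(=O)O)c2cc1Cl` differs from compound 2 by methoxy in place of isobutyl on an aromatic carbon. Because a 2.0-fold higher number from compound 1 to compound 2 (0.30 log units; within the scatter) stayed within the scatter, a second exchange at the same aromatic carbon is not expected to shift this assay beyond the scatter either. For compound 3 the expected result is 10 nM, with a range of 4 nM to 25 nM, corresponding to an estimated step of a 1.3-fold lower number from compound 2 to compound 3 (0.10 log units; within the scatter).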

Compound 3, half-maximal inhibitory concentration: 12.6 nM
Estimate against measurement, compound 3: 1.3-fold (0.10 log units) below; low and high end bracket the measured number.
By their numbers in this assay, from the lowest: compounds 1, 2 and 3 (each within the scatter of the next).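

With methoxy on this aromatic carbon, this assay shows no change at the digits printed from compound 2 to compound 3 (within the scatter) and a 2.0-fold higher number from compound 1 to compound 3 (0.30 log units; within the scatter) as the two readings of the new compound against the earlier ones. The carbon now carries three different groups across compound 1, compound 2 and compound 3, and no pair among them is separated beyond the scatter, so none of the compounds shown goes against a flat reading at this position. This holds although methoxy brings an oxygen and a hydrogen-bond acceptor where isobutyl has none and chloro stands in compound 1, and no measurement on hand bears on why the read-out stays flat.

Going by these compounds, whether an amine, a carboxylic acid or a longer chain on this aromatic carbon would also stay within the scatter remains open. Also open, on these data alone, is whether the flat reading would hold if the chloro group ortho to this carbon were exchanged for another group.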